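Hydroxy on the pendant aryl of compound 3

The compounds below may be only part of what the source reports. "The series", "measured", "known", "first", "only" and "open" are said of these compounds alone.

Measured so far in an assay on HEK293 cells for binding affinity to adenosine receptor A3 (Homo sapiens), read by radioligand binding; on this read-out lower numbers stand for stronger inhibition and higher numbers for weaker inhibition:
- compound 1, `COc1ccc(-c2oc3cc(OC)cc(OC)c3c(=O)c2OC)c(OC)c1`, gives 2650 nM
- compound 2, `Cc1ccc(-c2oc3ccc(Cl)cc3c(=O)c2Cl)c(OCC(C)C)c1`, gives 561 nM
- compound 3, `O=C1CC(c2ccccc2)Oc2ccccc21`, gives 50100 nM

Compound 3 stands at the top of the three numbers in this assay, that is, at the weak end. Compound 1 gives the nearest number, and it is still clearly lower than that of compound 3; compound 2 gives the lowest number of the set, furthest from compound 3. Within the data shown here, compound 3 is the only one of the three with a saturated core and without substituents on either ring, so no single-point step connects it to compound 1 or compound 2.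

Compound 4, `O=C1CC(c2ccccc2O)Oc2ccccc21`, is not yet measured in this assay. It differs from compound 3 in one place: hydroxy in place of hydrogen on an aromatic carbon. Nothing in the three measured compounds shows what a single hydroxy does on this core; compound 1 and compound 2 carry other groups on other cores, and their numbers give no direct guide. The expected step from compound 3 to compound 4 is therefore set small, close to no change and within the scatter, with a slight lean toward a lower number: a 1.6-fold lower number from compound 3 to compound 4 (0.19 log units; within the scatter). For compound 4 the estimate in this assay is 32000 nM, with a range from 8000 nM to 130000 nM.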

Compound 4, inhibition constant: 6070 nM
The estimate for compound 4 lay 5.3-fold (0.72 log units) above the measured number, outside the stated range (below it).
By their numbers in this assay, from the lowest: compound 2; then compound 1; then compound 4; then compound 3.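

In this assay, hydroxy in place of hydrogen on an aromatic carbon, ortho to a large group, gives an 8.3-fold lower number from compound 3 to compound 4 (0.92 log units; beyond the scatter), so this one change on an otherwise unsubstituted core is enough to move the number beyond the scatter. Among these compounds, the earlier compounds offered no single-point step, which makes this the first direct reading of what one substituent does: this position on the six-membered aromatic ring of carbon only responds to substitution, and the response runs toward a lower number. Nothing available here gives a reason for the step.

As far as these compounds go, a single pair cannot show whether the step is specific to hydroxy, so it remains open whether a methoxy, an amine or a fluorine at the same place would give a step of similar size and direction. Also open, from the compounds shown here alone, is whether hydroxy on another carbon of that ring, or the same change on the differently substituted cores of compound 1 and compound 2, would have a comparable effect.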